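The compounds below may be only part of what the source reports. "The series", "measured", "known", "first", "only" and "open" are said of these compounds alone.

Measured so far in a functional assay on KB cells (Homo sapiens) for antiproliferative activity, read by sulforhodamine B assay, with a stated time of 3 days; on this read-out higher numbers stand for an effect only at larger amounts of compound and lower numbers for an effect already at smaller amounts:
- compound 1 `CCC1=C(O)c2c(oc(-c3ccc(C(C)C)cc3)cc2=O)C(CC)(CC)C1=O`: 8.13 uM
- compound 2 `CCC1=C(O)c2c(oc(-c3ccccc3OC)cc2=O)C(CC)(CC)C1=O`: 40.8 uM

Of these two, compound 2 has the higher number, so it needs the larger amount of compound to show its effect. Compound 3 `CCC1=C(O)c2c(oc(-c3ccccc3F)cc2=O)C(CC)(CC)C1=O` has not yet been measured. It differs from compound 2 in one place: fluoro in place of methoxy on an aromatic carbon. In plain terms, this is fluoro in place of methoxy on an aromatic carbon, ortho to a large group.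

For the measured compounds named here, only one measured step bears on this, and only indirectly: a 5.0-fold higher number from compound 1 to compound 2 (0.70 log units; beyond the scatter). That modest step exchanged a whole group, 4-isopropylphenyl for 2-methoxyphenyl, whereas compound 3 alters only part of 2-methoxyphenyl. Going by the values given here, no measured compound carries fluoro, so the direction stays open, with only a slight lean towards a lower number. Among the compounds with values here, with a 5.0-fold higher number from compound 1 to compound 2 (0.70 log units; beyond the scatter) as the only guide to scale, a smaller step is expected here.

The estimated change is a 1.4-fold lower number from compound 2 to compound 3 (0.13 log units; within the scatter). For compound 3 the estimated value is 30 uM, with an expected range of 12 uM to 70 uM.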

Compound 3, concentration for half-maximal effect: > 56.2 uM
Compound 3: only a limit was reported; the forecaster's own chance of this, stated with the estimate: 10%; at least 1.8-fold (0.27 log units) between middle value and limit.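

For compound 3, this assay gives > 56.2 uM, which is a limit and not a number, so each comparison with this compound yields only a floor: the limit of > 56.2 uM in this assay, at which 1 of the 3 values shown sits. With fluoro in place of methoxy at this position, ortho to a large group, the result is an at least 1.3-fold higher number from compound 2 to compound 3 (0.13 log units; that floor lies within the scatter); this floor cannot show whether compound 3 truly differs from compound 2, but the exchange gives no sign of a lower number. The new information is that 2-fluorophenyl, like 2-methoxyphenyl, falls clearly short of the 4-isopropylphenyl compound, with an at least 6.9-fold higher number from compound 1 to compound 3 (0.83 log units; beyond the scatter).

Compound 1 differs from the other two in both the group and where it sits on the ring, so these compounds cannot show whether the group's identity, its place, or the loss of isopropyl matters most. Also open, as far as these compounds go, is how a chloro group, a hydroxyl or an amine at this position would behave, and how far the number of compound 3 actually lies past its limit.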